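This account rests on a few compounds, and the source may have more. Where it says the series, first, only, none or still open, it means among the compounds named here.

In a functional assay on HepG2 cells (Homo sapiens) for antiproliferative activity, read by MTT assay, with a stated time of 96 h (a lower number here means a stronger inhibitor of growth, a higher number a weaker inhibitor of growth), compound 2 (`CCCc1cc(-c2ccc(F)cc2)n(Cc2ccc(C(=O)NO)cc2)n1`) gives 6660 nM and compound 1 (`Cc1cc(-c2ccc(F)cc2)n(Cc2ccc(C(=O)NO)cc2)n1`) gives 3630 nM and the two stand within the scatter of each other. The change to compound 3 (`CCc1cc(-c2ccc(F)cc2)n(Cc2ccc(C(=O)NO)cc2)n1`) is hydrogen in place of methyl on a saturated chain carbon, two bonds along the chain from an aromatic carbon and reads in words as hydrogen in place of methyl on a saturated chain carbon, two bonds along the chain from an aromatic carbon. For the measured compounds named here, the only measured step bearing on it is a 1.8-fold higher number from compound 1 to compound 2 (0.26 log units; within the scatter) and it stays within the scatter. The expected step is a 1.4-fold lower number from compound 2 to compound 3 (0.13 log units; within the scatter) and nothing beyond the scatter is expected in this assay for this change. Compound 3 is estimated at 4900 nM (2800 nM to 8500 nM).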

Compound 3, concentration for 50% growth inhibition: 7760 nM
Estimate against measurement, compound 3: 1.6-fold (0.20 log units) below; measured number inside the range.
By their numbers in this assay, from the lowest: compounds 1, 2 and 3 (each within the scatter of the next, the first and the last beyond it).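

In this assay, going from propyl to ethyl produces no readable change (a 1.2-fold higher number from compound 2 to compound 3 (0.07 log units; within the scatter)). For the compounds shown here, the first step beyond the scatter at this position is the one between methyl and ethyl (a 2.1-fold higher number from compound 1 to compound 3 (0.33 log units; beyond the scatter)), and it is modest, while compound 2 stays within the scatter of both compound 1 and compound 3. Nothing measured here accounts for these steps. As far as these compounds go, whether a longer chain such as butyl, an amine or a carboxylic acid in place of the ethyl would move the number stays open, as does the effect of hydrogen in place of the methyl of compound 1.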